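Biphenyl in Place of Phenyl: Cytotoxicity of Two Cores

This account rests on a few compounds, and the source may have more. Where it says the series, first, only, none or still open, it means among the compounds named here.

Measured so far:
compound 1 `CN1Cc2ccc(O)cc2[C@@H](OCc2ccccc2)C1` — > 50000 nM
compound 2 `CN1Cc2ccc(O)cc2[C@@H](OCc2ccc(-c3ccccc3)cc2)C1` — > 50000 nM
compound 3 `CN1CCc2cc(OCc3ccccc3)ccc2C1` — > 100000 nM

In an ADME assay on Vero cells (Chlorocebus sabaeus) for cytotoxicity, read by sulforhodamine B assay, with a stated time of 72 h (a lower number here means a stronger inhibitor, a higher number a weaker inhibitor), compound 1 reaches only a limit of the assay, > 50000 nM. Compound 2 likewise reaches only a limit in this assay, > 50000 nM. The change from compound 1 to compound 2 is phenyl in place of hydrogen on an aromatic carbon. Its size is not readable: a step that the two limits leave unreadable from compound 1 to compound 2. Both values sit at the limit described by the limit of > 50000 nM in this assay, at which 2 of the 3 values shown sit.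

Compound 3 is built on a different core. How the core of compound 3 differs from the core of compound 1 is not broken down here. In this assay compound 3 also reaches only a limit, > 100000 nM, the one described by the limit of > 100000 nM in this assay, at which 1 of the 3 values shown sits.

Compound 4 `CN1CCc2cc(OCc3ccc(-c4ccccc4)cc3)ccc2C1` has not yet been measured in this assay. It differs from compound 3 by phenyl in place of hydrogen on an aromatic carbon, the same change as that from compound 1 to compound 2, with the same surroundings at the place of the change. For compound 4 in this assay the step of a number no higher from compound 3 to compound 4 (the limit leaves the size open) is expected, resting on the fact that compound 3 gives > 100000 nM and that the same change left compound 2 at a limit, > 50000 nM. The estimate for compound 4 in this assay is 100000 nM, from 40000 nM to 300000 nM, most probably reported only as a limit.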

Compound 4, half-maximal inhibitory concentration: 16500 nM
For compound 4 the middle estimate is 6.1-fold (0.78 log units) above the measured one; measured number outside the range, below it.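

In this assay, phenyl in place of hydrogen on an aromatic carbon gives an at least 6.0-fold lower number from compound 3 to compound 4 (0.78 log units; beyond the scatter), which makes compound 4 the only compound shown with a measured number rather than a limit. What the same change does on the core of compound 1 cannot be read, because compound 1 and compound 2 both stay at a limit: the limit of > 50000 nM in this assay, at which 2 of the 4 values shown sit. The result therefore shows that this change can strengthen the effect on the core of compound 3, but it does not show whether the effect carries over to the core of compound 1 or how large the full step is, because the step starts from a limit: the limit of > 100000 nM in this assay, at which 1 of the 4 values shown sits.

On these data alone, it stays open whether the phenyl ring is needed for the drop, or whether a smaller group at the same place, such as methyl or chlorine, would move the number in the same direction. As far as these compounds go, it is also open whether a phenyl ring carrying an amine or a carboxylic acid would keep the number of compound 4, and whether a longer chain between the two rings would change it.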